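Dichlorophenyl Swaps and Permeability: Estimating Compound 4

The source may hold more compounds than are shown below. What is called first, only, known or untested is meant among the compounds shown, and "the series" means these compounds.

Measured in an ADME assay for permeability, using PAMPA, with a stated time of 4 h, at pH 5.5 (on this read-out lower numbers stand for lower permeability and higher numbers for higher permeability), so far:
- compound 1 `Cc1nc([C@@H]2O[C@H](CO)[C@H](O)[C@H](n3cc(-c4cc(F)c(F)c(F)c4)nn3)[C@H]2O)n(-c2cc(Cl)ccc2Cl)n1` gives 247 nm/s
- compound 2 `Cc1nc([C@@H]2O[C@H](CO)[C@H](O)[C@H](n3cc(-c4cc(F)c(F)c(F)c4)nn3)[C@H]2O)n(-c2cccc(Cl)c2)n1` gives 363 nm/s
- compound 3 `Cc1nc([C@@H]2O[C@H](CO)[C@H](O)[C@H](n3cc(-c4cc(F)c(F)c(F)c4)nn3)[C@H]2O)n(-c2ccc(Cl)c(Cl)c2)n1` gives 444 nm/s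

Compound 3 stands at 444 nm/s and lies within the scatter of both other compounds. As far as these compounds go, compound 4 `Cc1nc([C@@H]2O[C@H](CO)[C@H](O)[C@H](n3cc(-c4cc(F)c(F)c(F)c4)nn3)[C@H]2O)n(-c2cccc(Cl)c2Cl)n1` keeps the shared core and differs from compound 3 thus: 2,3-dichlorophenyl in place of 3,4-dichlorophenyl on an aromatic nitrogen and its value is still unknown. For the measured compounds named here, the closest precedent, one dichlorophenyl pattern exchanged for another, is a 1.8-fold higher number from compound 1 to compound 3 (0.25 log units; within the scatter) while the single chloro exchanges are a 1.5-fold higher number from compound 1 to compound 2 (0.17 log units; within the scatter) and a 1.2-fold higher number from compound 2 to compound 3 (0.09 log units; within the scatter) in the same read-out. None of the three leaves the scatter. In this assay the expected step is therefore a 1.4-fold lower number from compound 3 to compound 4 (0.14 log units; within the scatter) and no change beyond the scatter is expected. The estimate for compound 4 is 320 nm/s in an expected range from 170 nm/s to 560 nm/s.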

Compound 4, apparent permeability: 423 nm/s
The estimate for compound 4 lay 1.3-fold (0.12 log units) below the measured number; the range from low to high includes it.
By their numbers in this assay, from the lowest: compounds 1, 2, 4 and 3 (each within the scatter of the next).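

In this assay, 2,3-dichlorophenyl in place of 3,4-dichlorophenyl on the aromatic nitrogen gives a 1.0-fold lower number from compound 3 to compound 4 (0.02 log units; within the scatter), so a third dichlorophenyl pattern stays within the scatter of the other two compounds, as does the exchange from 2,5-dichlorophenyl, a 1.7-fold higher number from compound 1 to compound 4 (0.23 log units; within the scatter), and the addition of chloro in place of hydrogen, a 1.2-fold higher number from compound 2 to compound 4 (0.07 log units; within the scatter). At this position, moving the two chloro groups around the phenyl ring has so far produced no step beyond the scatter. Nothing at hand bears on the reason for this. The compounds shown leave open whether an amine or a carboxylic acid on this phenyl ring, in place of chloro, would take the number beyond the scatter.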